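This account rests on a few compounds, and the source may have more. Where it says the series, first, only, none or still open, it means among the compounds named here.

Two measured compounds frame the question. Compound 1 `Cc1ccc(NC(=O)[C@@H]2CCCN2S(=O)(=O)c2cccc3cccnc23)cc1` and compound 2 `Cc1cc(C)cc(NC(=O)[C@@H]2CCCN2S(=O)(=O)c2cccc3cccnc23)c1` share one core and differ only in the aryl group on the amide-type nitrogen. In an ADME assay on HEp-2 cells (Homo sapiens) for cytotoxicity (a lower number here means that less compound is tolerated, a higher number that more compound is tolerated), compound 1 gives 31700 nM, and in this assay compound 2 gives 31300 nM. The step between them, a 1.0-fold lower number from compound 1 to compound 2 (0.01 log units; within the scatter), is the only one on record, and it stays within the scatter. Among the measured compounds shown here, compound 2 therefore stands beside compound 1, the only other measured compound, with a gap that the scatter covers; nothing separates the two numbers.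

Compound 3 `Cc1ccc(C(C)C)cc1NC(=O)[C@@H]1CCCN1S(=O)(=O)c1cccc2cccnc12` is not yet measured. It differs from compound 2 by 5-isopropyl-2-methylphenyl in place of 3,5-dimethylphenyl on an amide-type nitrogen. For the measured compounds named here, the one step that bears on this change is the swap of one substituted phenyl for another between compound 1 and compound 2, which moved the number by a 1.0-fold lower number from compound 1 to compound 2 (0.01 log units; within the scatter). On that basis, no step beyond the scatter is expected in this assay for compound 3, in either direction. The estimated step from compound 2 to compound 3 is a 1.0-fold lower number from compound 2 to compound 3 (0.02 log units; within the scatter), expected to lie within the scatter. For compound 3 in this assay the expected value is 30000 nM, with a range from 15000 nM to 60000 nM.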

Compound 3, half-maximal cytotoxic concentration: 9700 nM
Compound 3: middle estimate off by 3.1-fold (0.49 log units), on the high side; the whole stated range lies above it.
By their numbers in this assay, from the lowest: compound 3; then compounds 2 and 1 (each within the scatter of the next).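

Among the aryl groups on the amide-type nitrogen, the swap between compound 1 and compound 2 had left the number in this assay level, but 5-isopropyl-2-methylphenyl brings a 3.2-fold lower number from compound 2 to compound 3 (0.51 log units; beyond the scatter) and likewise a 3.3-fold lower number from compound 1 to compound 3 (0.51 log units; beyond the scatter) as modest steps that both lie beyond the scatter. This shows that the aryl group at this place is not interchangeable in this assay: the measured 4-methylphenyl and 3,5-dimethylphenyl compounds stand level, and compound 3, with 5-isopropyl-2-methylphenyl, is tolerated at the lowest concentration of the three. Nothing on hand explains this fall in the number.

Compound 3 changes the set of substituents on the phenyl ring in a single step, and the compounds shown do not separate what the isopropyl group contributes from what the altered placement of the methyl group contributes. As far as these compounds go, it also remains open whether an amine or a carboxylic acid on this phenyl ring, or a longer alkyl chain in place of the isopropyl group, would restore the number, leave it unchanged or lower it further.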